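A few compounds are considered here, and "the series" means these few. Any claim that something is new, unique, unknown or untested is made for them only; others in the source may bear on it.

Measured so far, in a functional assay on U-87MG ATCC cells for antiproliferative activity against U-87 MG (Homo sapiens), read by MTT assay, with a stated time of 48 h, tested at 5 uM; on this read-out higher numbers stand for a weaker effect at the one concentration tested and lower numbers for a stronger effect:
Compound 1, `COc1ccc(-c2nc(C)c(C(=O)CSc3nc(-c4ccc(Cl)cc4)c(C#N)c(=O)[nH]3)s2)cc1`, gives 102%.
Compound 2, `COc1ccc(-c2nc(C)c(C(=O)CSc3nc(-c4cccc(OC)c4)c(C#N)c(=O)[nH]3)s2)cc1`, gives 71.3%.
Compound 3, `Cc1nc(-c2ccc(Cl)cc2)sc1C(=O)CSc1nc(-c2ccc(Cl)cc2)c(C#N)c(=O)[nH]1`, gives 99%.

Compound 4, `COc1cccc(-c2nc(SCC(=O)c3sc(-c4ccc(Cl)cc4)nc3C)[nH]c(=O)c2C#N)c1`, has not yet been measured in this assay. It differs from compound 3 in one place: 3-methoxyphenyl in place of 4-chlorophenyl on an aromatic carbon. The same change has already been measured once, going from compound 1 to compound 2: 3-methoxyphenyl in place of 4-chlorophenyl on an aromatic carbon. There it made a large step, a number 30.7 percentage points lower from compound 1 to compound 2 (beyond the scatter), beyond the scatter of repeated measurements of this kind. The two starting points, compound 1 and compound 3, differ only in their cores: chloro in place of methoxy on an aromatic carbon. The step that goes with this core difference, a number 3 percentage points lower from compound 1 to compound 3 (within the scatter), lies within the scatter. The surroundings of the exchanged group read the same word for word in both pairs, so the change from compound 3 to compound 4 is the same change as the one already seen. Because a number 30.7 percentage points lower from compound 1 to compound 2 (beyond the scatter) was large and compound 3 starts within the scatter of compound 1, a step of similar size is expected here, a number 29 percentage points lower from compound 3 to compound 4 (beyond the scatter). For compound 4 the estimate is 70%, most likely between 50% and 92%.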

Compound 4, a percentage reported as activity, at one concentration (the size of the read-out at that concentration, not a potency): 96.6%
Compound 4: the middle estimate sits 26.6 percentage points below what was measured, outside the stated range (above it).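

In this assay, 3-methoxyphenyl in place of 4-chlorophenyl gave a number 2.4 percentage points lower from compound 3 to compound 4 (within the scatter), so the large step seen on the core of compound 1 did not carry over to the core of compound 3: the same change on two cores in this assay, a number 30.7 percentage points lower (beyond the scatter) from compound 1 to compound 2 and a number 2.4 percentage points lower (within the scatter) from compound 3 to compound 4, 28.3 percentage points apart, beyond the scatter of two such steps. The mismatch also appears from the other side, where chloro in place of methoxy gave a number 25.3 percentage points higher from compound 2 to compound 4 (beyond the scatter): the same change on two cores in this assay, a number 3 percentage points lower (within the scatter) from compound 1 to compound 3 and a number 25.3 percentage points higher (beyond the scatter) from compound 2 to compound 4, 28.3 percentage points apart, beyond the scatter of two such steps. So in these four compounds the result of one exchange depends on the group at the other site, and a step measured on one core cannot simply be transferred to another, but the data do not show why, and compound 2 alone stands apart, so this rests on a single compound.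

Still open, on these data alone, is whether the lower number of compound 2 would persist if its methoxy groups gave way to other groups, such as an amine or a longer ether chain. A reading at one concentration also leaves open how these compounds would compare across a range of concentrations.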